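Lengthening the ether chain on a pyrazole amide core

The source may report more compounds than this note shows. Statements on the series, on what has been measured and on what is new or still open speak of the compounds shown alone.

Of the compounds shown here, two of a shared core have been tested in a functional assay on the whole organism (strain Wistar) for inhibition, with Rattus norvegicus as the target, read by paw edema, with stated times of 30 min and 3 h, at a dose of 100 mg/kg by the oral route; a lower number here means less inhibition, a higher number more inhibition at the dose given (going by the name of the read-out). Compound 1 `COc1cc(C(=O)NC(C)C)nn1-c1ccccc1` gives 24.8% in this assay. Compound 2 `CCOc1cc(C(=O)N(C)C)nn1-c1ccccc1` gives 65.8% in this assay, the higher of the two numbers, and its gap to compound 1 lies beyond the usual scatter. Compound 3 `CCCCOc1cc(C(=O)N(C)C)nn1-c1ccccc1` has not yet been measured. It differs from compound 2 in one place: ethyl in place of hydrogen on a saturated chain carbon, two bonds along the chain from an oxygen on an aromatic ring. Among the measured compounds shown here, no measured pair shows what such a lengthening does here, so the expected step of a number 10.8 percentage points lower from compound 2 to compound 3 (beyond the scatter) is small, if any beyond the scatter. Compound 3 is expected to give about 55% in this assay, somewhere between 35% and 75%.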

Compound 3, a percentage reported as inhibition, in the whole organism at one dose (the size of the read-out at that dose, not a potency): 18.7%
Compound 3: the middle estimate sits 36.3 percentage points above what was measured; measured number below the stated range.
By their numbers in this assay, from the lowest: compounds 3 and 1 (each within the scatter of the next); then compound 2.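

In this assay the change from ethoxy to butoxy, with nothing else altered, brings a number 47.1 percentage points lower from compound 2 to compound 3 (beyond the scatter) and so shows that this ether chain does not accept added length freely. Adding just an ethyl at this one place is enough to take away most of the inhibition seen with compound 2. No measurement shown here accounts for the drop.

As far as these compounds go, whether the loss builds gradually or appears suddenly remains open. Propoxy on the same core would show what happens at the intermediate length, and methoxy would show whether a shorter chain is better or worse than ethoxy.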